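A few compounds are considered here, and "the series" means these few. Any claim that something is new, unique, unknown or untested is made for them only; others in the source may bear on it.

Measured so far:
- compound 1 (`O=C(NC(=S)N1CCc2c(OCCCCCOc3ccc(Cl)cc3)cccc21)c1ccc(F)cc1`), which in an ADME assay on Huh-7 cells (Homo sapiens) for cytotoxicity (on this read-out higher numbers stand for lower toxicity in this test and lower numbers for higher toxicity in this test), gives 31100 nM as a measured number
- compound 2 (`O=C(NC(=S)N1CCc2c(OCCCCCOc3ccc(Cl)cc3)cccc21)C1CCCC1`), for which this assay reports only the limit > 50000 nM and no number

Compound 2 therefore stands at the limit of this assay, and all that is known is that its value lies at or beyond it (the limit of > 50000 nM in this assay, at which 1 of the 2 values shown sits). Compound 3 (`O=C(NC(=S)N1CCc2c(OCCCCCOc3ccc(Cl)cc3)cccc21)c1ccoc1`) differs from compound 2 in one place: furan-3-yl in place of cyclopentyl on a carbonyl carbon. Among the compounds with values here, the only measured step that bears on this is the one into compound 2, an at least 1.6-fold higher number from compound 1 to compound 2 (0.20 log units; that floor lies within the scatter), where a non-aromatic ring replaced an aromatic one; the step into compound 3 reverses that direction by bringing an aromatic ring back. A modest movement toward the number of compound 1 is therefore expected, though the step is small enough that compound 3 may again fall at the limit. For compound 3 the expected value in this assay is 40000 nM (18000 nM to 90000 nM), an expected step of an at least 1.2-fold lower number from compound 2 to compound 3 (0.09 log units; that floor lies within the scatter).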

Compound 3, half-maximal cytotoxic concentration: 20100 nM
Estimate against measurement, compound 3: 2.0-fold (0.30 log units) above; the measured number falls inside the stated range.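

In this assay, this carbonyl position now shows a change beyond the scatter, with furan-3-yl in place of cyclopentyl: an at least 2.4-fold lower number from compound 2 to compound 3 (0.39 log units; beyond the scatter). Compound 2 is reported only as a limit, so only the floor of that step is known: the limit of > 50000 nM in this assay, at which 1 of the 3 values shown sits. The two aromatic rings on this carbonyl carbon, furan-3-yl and 4-fluorophenyl, cannot be told apart here: a 1.5-fold lower number from compound 1 to compound 3 (0.19 log units; within the scatter).

Going by these compounds, with only these three groups, it remains open whether the shift follows from the aromatic ring itself or from the ring oxygen of furan-3-yl, and tetrahydrofuran-3-yl, the non-aromatic ring with the same oxygen, would separate the two. Also open, on these data alone, is how an open-chain group such as tert-butyl, or a ring carrying an amine, would read out at this position.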